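Methyl on the ring carbon: from compound 3 to compound 4

The source may report more compounds than this note shows. Statements on the series, on what has been measured and on what is new or still open speak of the compounds shown alone.

Measured compounds:
compound 1 `C=C1CN(C)N(c2ccc(Cl)cc2)C1=O` 51900 nM
compound 2 `C=C1C(=O)N(c2ccccc2)N(c2ccccc2)C1C` 6980 nM
compound 3 `C=C1CN(C)N(c2ccccc2)C1=O` 56000 nM

In a functional assay on NALM-6 cells (Homo sapiens) for inhibition, read by MTT assay, with a stated time of 48 h (a lower number here means a stronger inhibitor, a higher number a weaker inhibitor), compound 3 gives the highest number of the three, close to compound 1 and well apart from compound 2, which differs from it in two places. Compound 4 `C=C1C(=O)N(c2ccccc2)N(C)C1C` carries methyl in place of hydrogen on a saturated ring carbon. Among the measured compounds shown here, no measured step isolates this change; the only single-point step, a 1.1-fold higher number from compound 1 to compound 3 (0.03 log units; within the scatter), concerns a different position and lies within the scatter, so it gives no guide. Compound 2, which also bears the methyl on that carbon, shows a lower number. Compound 2 differs from compound 3 in a second place as well, so its value alone cannot be tied to the methyl. The step from compound 3 to compound 4 is therefore expected to be modest, a 1.9-fold lower number from compound 3 to compound 4 (0.27 log units; within the scatter), with wide uncertainty. Compound 4 is estimated at 30000 nM, between 8000 nM and 100000 nM.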

Compound 4, half-maximal inhibitory concentration: 412000 nM
Beside the measured number, compound 4's estimate is 14-fold (1.14 log units) below it; measured number outside the range, above it.
By their numbers in this assay, from the lowest: compound 2; then compounds 1 and 3 (each within the scatter of the next); then compound 4.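

Methyl in place of hydrogen on the saturated ring carbon makes the compound a weaker inhibitor in this assay, with a 7.4-fold higher number from compound 3 to compound 4 (0.87 log units; beyond the scatter). Methyl in place of phenyl on the ring nitrogen gives the larger step, a 59-fold higher number from compound 2 to compound 4 (1.77 log units; beyond the scatter), so the low number of compound 2 goes with that phenyl and not with the ring-carbon methyl. Nothing measured here explains either step.

Still open, from the compounds shown here alone, is how an ethyl group or a longer chain on that ring carbon would read. Going by these compounds, a benzyl group on the ring nitrogen is equally open.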